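Restoring an aryl group on the ring nitrogen of compound 3

The source may report more compounds than this note shows. Statements on the series, on what has been measured and on what is new or still open speak of the compounds shown alone.

Three compounds share a core carrying an amide-bearing side chain, and differ only in the group on an amide-type nitrogen in a ring. In a functional assay on HOS-TE85 cells (Homo sapiens) for inhibition, read by CCK-8 assay, with a stated time of 72 h, tested at 1 uM (on this read-out higher numbers stand for more inhibition at the one concentration tested (going by the name of the read-out) and lower numbers for less inhibition), compound 1 `COc1ccc(F)cc1N1C(=O)CSC1c1cccc(C(=O)NCCCCc2ccccc2)c1` gives 95% and compound 2 `Cc1cccc(N2C(=O)CSC2c2cccc(C(=O)NCCCCc3ccccc3)c2)c1` gives 96%; the two lie apart by a number 1 percentage points higher from compound 1 to compound 2 (within the scatter). Compound 3 `CCN1C(=O)CSC1c1cccc(C(=O)NCCCCc2ccccc2)c1` gives 0% and stands lowest of the three, set apart from both others beyond the scatter. The steps of a number 95 percentage points lower from compound 1 to compound 3 (beyond the scatter) and a number 96 percentage points lower from compound 2 to compound 3 (beyond the scatter) each show a very large loss when a substituted phenyl group on that nitrogen is exchanged for ethyl. Compound 4 `COc1cc(F)ccc1N1C(=O)CSC1c1cccc(C(=O)NCCCCc2ccccc2)c1` reverses that kind of change: 4-fluoro-2-methoxyphenyl in place of ethyl on an amide-type nitrogen in a ring. Both steps that bear on this exchange therefore point to a large gain in this assay, with compound 1 and compound 2 showing that two quite different substituted phenyl groups reach the same high level. This step is expected to be a number 90 percentage points higher from compound 3 to compound 4 (beyond the scatter). Compound 4 is expected to give 90%, within a range from 65% to 99%.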

Compound 4, a percentage reported as inhibition, at one concentration (the size of the read-out at that concentration, not a potency): 94%
The estimate for compound 4 lay 4 percentage points below the measured number; the measured number falls inside the stated range.
By their numbers in this assay, from the lowest: compound 3; then compounds 4, 1 and 2 (each within the scatter of the next).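

In this assay, putting 4-fluoro-2-methoxyphenyl in place of ethyl on the ring nitrogen gives a number 94 percentage points higher from compound 3 to compound 4 (beyond the scatter), so the exchange has now been seen in the gaining direction as well as the losing one, and a third substituted phenyl group reaches the same high level. Changing the substituted phenyl group itself makes no readable difference: the step to the 4-fluoro-2-methoxyphenyl group from its 5-fluoro isomer is a number 1 percentage points lower from compound 1 to compound 4 (within the scatter), and the step from 3-methylphenyl is a number 2 percentage points lower from compound 2 to compound 4 (within the scatter). No measurement is at hand that explains the gap between these phenyl groups and ethyl.

The compounds shown leave open whether a benzyl or cyclohexyl group on this nitrogen would behave like the substituted phenyl groups or like ethyl. They also leave open whether an unsubstituted phenyl group would reach the same level.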